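Series notes: quinolin-6-yl variant at the aryl ether

The source may report more compounds than this note shows. Statements on the series, on what has been measured and on what is new or still open speak of the compounds shown alone.

Measured so far:
compound 1 `CCCCC(Sc1ccc(OCCCOc2cccc(C)c2)cc1)C(=O)O` — 4800 nM
compound 2 `CCCCC(Sc1ccc(OCCCOc2ccc(Cl)cc2OC)cc1)C(=O)O` — > 10000 nM

In an assay on isolated protein for inhibition of Polyunsaturated fatty acid 5-lipoxygenase (Homo sapiens), read by HPLC, with a stated time of 15 min, in the presence of a further agent that is not named here (a higher number here means a weaker inhibitor, a lower number a stronger inhibitor), compound 1 gives 4800 nM. For compound 2 the result in this assay is only a limit, > 10000 nM, as noted in the limit of > 10000 nM in this assay, at which 1 of the 2 values shown sits. For the measured compounds named here, the one measured step, an at least 2.0-fold higher number from compound 1 to compound 2 (0.31 log units; beyond the scatter), concerns the same aryl group on the oxygen on the saturated carbon. Compound 3 `CCCCC(Sc1ccc(OCCCOc2ccc3ncccc3c2)cc1)C(=O)O` carries quinolin-6-yl in place of 4-chloro-2-methoxyphenyl on an oxygen on a saturated carbon. Going by the values given here, no measured step covers a quinolinyl group, so the expectation rests on both neighbours; a change of an at least 1.2-fold lower number from compound 2 to compound 3 (0.09 log units; that floor lies within the scatter) from the limit is expected, with compound 3 estimated at 8000 nM (range 2000 nM to 30000 nM).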

Compound 3, half-maximal inhibitory concentration: > 10000 nM
Compound 3: no number, only a limit; the forecaster's own chance of this, stated with the estimate: 45%; middle value at least 1.2-fold (0.09 log units) away from the limit.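

In this assay compound 3 gives > 10000 nM, which is a limit and not a number. Quinolin-6-yl in place of 3-methylphenyl gives an at least 2.0-fold higher number from compound 1 to compound 3 (0.31 log units; beyond the scatter), so on this oxygen on a saturated carbon, a weaker result than that of 3-methylphenyl is no longer confined to 4-chloro-2-methoxyphenyl. The step between the two limits cannot be read, and quinolin-6-yl and 4-chloro-2-methoxyphenyl cannot be ranked: the limit of > 10000 nM in this assay, at which 2 of the 3 values shown sit.

Going by these compounds, it remains open whether any group at this place, such as an unsubstituted phenyl or a dimethylamino-bearing phenyl, gives a lower number than 3-methylphenyl. A longer chain in place of the saturated chain also remains untested among the compounds shown here.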